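Carbonyl aryl groups: the step from compound 3 to compound 4

The source may report more compounds than this note shows. Statements on the series, on what has been measured and on what is new or still open speak of the compounds shown alone.

In an ADME assay on Vero cells (Chlorocebus sabaeus) for cytotoxicity, read by trypan blue exclusion, with a stated time of 24 h (on this read-out higher numbers stand for weaker inhibition and lower numbers for stronger inhibition), compound 3 `COc1cc(C[C@@H](C)[C@@H](C)Cc2ccc(OC(=O)c3ccccc3)c(OC)c2)ccc1O` gives 125 ug/mL. Compound 1 `COc1cc(C[C@@H](C)[C@@H](C)Cc2ccc(OC(=O)c3cccnc3)c(OC)c2)ccc1O` gives 71.4 ug/mL, and compound 2 `COc1cc(C[C@@H](C)[C@@H](C)Cc2ccc(OC(=O)c3ccccn3)c(OC)c2)ccc1O` gives 65 ug/mL. These three values are not separated: a 1.8-fold higher number from compound 1 to compound 3 (0.24 log units; within the scatter) and a 1.9-fold higher number from compound 2 to compound 3 (0.28 log units; within the scatter) are both within the scatter, so compound 3 holds no distinct place in this small set.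

Compound 4 `COc1cc(C[C@@H](C)[C@@H](C)Cc2ccc(OC(=O)c3ccc(Br)cc3)c(OC)c2)ccc1O` shares the core of compound 3 and differs at one place, where the phenyl on the carbonyl becomes 4-bromophenyl: bromo in place of hydrogen on an aromatic carbon.

The measured steps closest to this change are the exchanges of the group on the same carbonyl, namely the two above and a 1.1-fold lower number from compound 1 to compound 2 (0.04 log units; within the scatter), which is also within the scatter. None of them introduces a bromo, so the data give no direct measure of this change. Within the data shown here, they show only that three different groups at this place remain indistinguishable in this assay. No step beyond the scatter is therefore expected, and no direction can be favoured with confidence. The expected step is a 1.2-fold lower number from compound 3 to compound 4 (0.08 log units; within the scatter). For compound 4 the estimated value is 105 ug/mL, with an expected range from 50 ug/mL to 200 ug/mL.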

Compound 4, half-maximal inhibitory concentration: 112 ug/mL
Compound 4: middle estimate off by 1.1-fold (0.03 log units), on the low side; measured number inside the range.
By their numbers in this assay, from the lowest: compounds 2, 1, 4 and 3 (each within the scatter of the next).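

Working notes on the carbonyl aryl position: in this assay, bromo in place of hydrogen on an aromatic carbon, para to a large group, gives the first reading of a substituent on this phenyl ring (a 1.1-fold lower number from compound 3 to compound 4 (0.05 log units; within the scatter)), and the step does not separate 4-bromophenyl from phenyl. The comparisons with the two pyridyl compounds read the same way (a 1.7-fold higher number from compound 2 to compound 4 (0.24 log units; within the scatter); a 1.6-fold higher number from compound 1 to compound 4 (0.20 log units; within the scatter)), so a fourth group on the same carbonyl, and the first to carry a halogen, also stays unresolved from the others, with every pair among compounds 1 to 4 inside the scatter. The series now spans a hydrogen-to-bromo exchange as well as the exchanges of ring type without yielding any step that can be read as a real difference, and no supporting data bear on the reason for this flat picture.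

Still open, as far as these compounds go, is whether an amine or a carboxylic acid in place of the bromo, or a longer chain on the carbonyl, would give a step beyond the scatter. Also open, from the compounds shown here alone, is how the number responds to changes elsewhere, such as replacing the ester link with an amide or altering the free hydroxy group on the far side of the shared core.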